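Ring-Substituted Coumarin Lipoamide Conjugates in PC-12 Cells

This account rests on a few compounds, and the source may have more. Where it says the series, first, only, none or still open, it means among the compounds named here.

Measured compounds and their values:
compound 1 `CCOC(=O)c1cc2ccc(OCCCn3cc(CNC(=O)CCCCC4CCSS4)nn3)cc2oc1=O`: 28.3%
compound 2 `O=C(CCCCC1CCSS1)NCc1cn(CCCCOc2ccc3cc(-c4ccccc4)c(=O)oc3c2)nn1`: 34.8%
compound 3 `CCOC(=O)c1cc2ccc(OCCCCCn3cc(CNC(=O)CCCCC4CCSS4)nn3)cc2oc1=O`: 35.1%

In a functional assay on PC-12 cells (Rattus norvegicus) for cytotoxicity, read by MTT assay, with stated times of 3 h and 2 h, tested at 1 uM (a higher number here means a stronger effect of the compound at the concentration tested, a lower number a weaker effect), compound 3 gives 35.1%, the highest of the three numbers shown, but its nearest neighbour compound 2 gives 34.8%, and even the furthest, compound 1 with 28.3%, sits within the scatter of compound 3. Among the compounds with values here, the three values are therefore indistinguishable, and no compound can be called the most active.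

Compound 4 `O=C(CCCCC1CCSS1)NCc1cn(CCCCCOc2ccc3cc(-c4ccc(Br)cc4)c(=O)oc3c2)nn1` has not yet been measured in this assay. It differs from compound 3 by one change: 4-bromophenyl in place of ethoxycarbonyl on an aromatic carbon

Within the data shown here, no step between measured compounds is available to gauge this change directly. Compound 2, which carries an aromatic group at the same place and gives 34.8%, is within the scatter of compound 3, so the change is expected to move the value in this assay by little, if anything, with perhaps a slight upward drift.

The step from compound 3 to compound 4 is estimated as a number 2.9 percentage points higher from compound 3 to compound 4 (within the scatter) and judged as likely to fall within the scatter.

Compound 4 is thus expected to give about 38% in this assay, with a likely range from 28% to 48%.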

Compound 4, a percentage reported as activity, at one concentration (the size of the read-out at that concentration, not a potency): 43.7%
Compound 4: middle estimate off by 5.7 percentage points, on the low side; measured number inside the range.
By their numbers in this assay, from the lowest: compounds 1, 2, 3 and 4 (each within the scatter of the next, the first and the last beyond it).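

In this assay, the step from ethoxycarbonyl to 4-bromophenyl, on the aromatic carbon two atoms from the ring oxygen, is a number 8.6 percentage points higher from compound 3 to compound 4 (within the scatter). Within the data shown here, this is the first direct reading at this position, and it shows that an ester with two hydrogen-bond acceptors can give way to an aromatic ring with none, and with more heavy atoms, without the number leaving the scatter. Nothing measured here explains the size of this step.

The compounds shown leave open what the bromine adds to the phenyl ring at this position, since the step covers the ring and the halogen together. They also leave open whether a carboxylic acid or an amine at the same carbon would carry the number beyond the scatter.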